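From 1H-indol-2-yl to quinolin-2-yl on a shared core

The source may hold more compounds than are shown below. What is called first, only, known or untested is meant among the compounds shown, and "the series" means these compounds.

Measured so far:
compound 1 `CCN1CCN(c2cc(C)c3cc(NC(=O)c4ccc(C)cc4)ccc3n2)CC1`: 6740 nM
compound 2 `CCN1CCN(c2cc(C)c3cc(NC(=O)c4ccc(F)c(F)c4)ccc3n2)CC1`: 5230 nM
compound 3 `CCN1CCN(c2cc(C)c3cc(NC(=O)c4cc5ccccc5[nH]4)ccc3n2)CC1`: 2950 nM

These compounds differ only in the group on the carbonyl carbon. In a functional assay on MCF7 cells (Homo sapiens) for antiproliferative activity, read by MTT assay, with a stated time of 72 h (on this read-out lower numbers stand for stronger inhibition and higher numbers for weaker inhibition), compound 3 separates from only one of the other two: a 2.3-fold lower number from compound 1 to compound 3 (0.36 log units; beyond the scatter), but a 1.8-fold lower number from compound 2 to compound 3 (0.25 log units; within the scatter).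

Compound 4 `CCN1CCN(c2cc(C)c3cc(NC(=O)c4ccc5ccccc5n4)ccc3n2)CC1`, not yet measured, has quinolin-2-yl in place of 1H-indol-2-yl on a carbonyl carbon.

Swaps at this place have stayed small, with a 1.3-fold lower number from compound 1 to compound 2 (0.11 log units; within the scatter) as well, and the largest of the three is only modest. No step beyond the scatter is therefore expected in this assay, in either direction. The expected step is a 1.2-fold higher number from compound 3 to compound 4 (0.07 log units; within the scatter). The estimate for compound 4 is 3500 nM, with an expected range from 1500 nM to 7500 nM.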

Compound 4, half-maximal inhibitory concentration: 7060 nM
For compound 4 the middle estimate is 2.0-fold (0.30 log units) below the measured one, and the stated range covers the measured number.
By their numbers in this assay, from the lowest: compounds 3, 2, 1 and 4 (each within the scatter of the next, the first and the last beyond it).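

A group with two aromatic rings on the carbonyl carbon does not by itself keep the low number of compound 3, as quinolin-2-yl gives a 2.4-fold higher number from compound 3 to compound 4 (0.38 log units; beyond the scatter). Compound 4 instead stays level with the single-ring groups, with a 1.3-fold higher number from compound 2 to compound 4 (0.13 log units; within the scatter) and a 1.0-fold higher number from compound 1 to compound 4 (0.02 log units; within the scatter). The swap also trades a hydrogen-bond donor for an acceptor, but nothing measured here links that difference to the shift. On these data alone, it remains open whether 1-methyl-1H-indol-2-yl, which replaces the hydrogen on the indole nitrogen with methyl, would match compound 3. As far as these compounds go, the effect of an amine on the phenyl ring is also open.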